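Replacing the Carboxy-Methoxyphenyl Group with Pyridin-3-yl

The compounds below may be only part of what the source reports. "The series", "measured", "known", "first", "only" and "open" are said of these compounds alone.

Compound 1 `CN1CCC[C@H](OCc2cc(Cl)cc(Cl)c2)[C@@H]1c1ccccc1`: in an assay on isolated protein for activation of cGMP-dependent protein kinase 1 (Homo sapiens), read by ADP-Glo, with stated times of 120 min and 40 min (a lower number here means that less compound is needed, a higher number that more compound is needed for the effect), compound 1 gives > 200000 nM, which is a limit of the assay rather than a number.
Compound 2 `Clc1cc(Cl)cc(CO[C@H]2CCCN(Cc3nccs3)[C@H]2c2ccccc2)c1`: in this assay compound 2 gives > 200000 nM, again only a limit.
Compound 3 `COc1cc(C(=O)O)ccc1CN1CCC[C@H](OCc2cc(Cl)cc(Cl)c2)[C@@H]1c1ccccc1`: in this assay compound 3 gives 62000 nM.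

Compound 3 is thus the only one of the three with a real number; the other two sit at the limit of > 200000 nM in this assay, at which 2 of the 3 values shown sit. Among the measured compounds shown here, two measured steps bear on the present question: an at least 3.2-fold lower number from compound 1 to compound 3 (0.50 log units; beyond the scatter) and an at least 3.2-fold lower number from compound 2 to compound 3 (0.50 log units; beyond the scatter). Both show that putting the 4-carboxy-2-methoxyphenyl group onto the saturated chain carbon bound to the ring amine nitrogen brings the number down from the limit into readable territory.

Compound 4 `Clc1cc(Cl)cc(CO[C@H]2CCCN(Cc3cccnc3)[C@H]2c2ccccc2)c1` takes that group away again: pyridin-3-yl in place of 4-carboxy-2-methoxyphenyl on a saturated chain carbon bound to an amine nitrogen in a ring. Compound 2, which carries a different small ring at the same place, sits at the limit, so there is no sign that a small ring alone keeps the number low. The change is therefore expected to push the number back up, by about a 2.9-fold higher number from compound 3 to compound 4 (0.46 log units; beyond the scatter). Compound 4 is estimated at 180000 nM, within a range from 60000 nM to 300000 nM, with a real chance that only a limit is reported.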

Compound 4, half-maximal effective concentration: 112000 nM
Beside the measured number, compound 4's estimate is 1.6-fold (0.21 log units) above it; the measured number falls inside the stated range.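

At this place, on a saturated chain carbon bound to an amine nitrogen in a ring, the 4-carboxy-2-methoxyphenyl group is not required for a readable number in this assay: pyridin-3-yl gives one too, and the step is a 1.8-fold higher number from compound 3 to compound 4 (0.26 log units; within the scatter), so compound 3 and compound 4 cannot be told apart. The comparisons with the two unreadable compounds are an at least 1.7-fold lower number from compound 2 to compound 4 (0.25 log units; that floor lies within the scatter) and an at least 1.7-fold lower number from compound 1 to compound 4 (0.25 log units; that floor lies within the scatter), and these floors alone do not set compound 4 clearly apart from either. Compound 1 and compound 2 therefore remain known only as limits of the assay, not as numbers: the limit of > 200000 nM in this assay, at which 2 of the 4 values shown sit.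

As far as these compounds go, whether a plain phenyl or a pyridin-4-yl group at this place would also give a readable number remains open. Also open, from the compounds shown here alone, is whether any group here can bring the number well down from that of compound 3, which gives 62000 nM.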